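Compound 1 to compound 4: methoxy to hydroxy

The source may report more compounds than this note shows. Statements on the series, on what has been measured and on what is new or still open speak of the compounds shown alone.

In a functional assay on LOX IMVI cells (Homo sapiens) for cytotoxicity, read by MTT assay, with a stated time of 24 h (a lower number here means a stronger inhibitor, a higher number a weaker inhibitor), compound 1 (`COc1cc(-c2nc(-c3ccccc3)[nH]c2-c2ccnc(NCCCNS(=O)(=O)c3ccc(Cl)cc3)n2)ccc1F`) gives 83100 nM, the highest of three numbers, against compound 2 (`COc1cc(-c2nc(-c3ccccc3)[nH]c2-c2ccnc(NCCCNS(=O)(=O)c3ccc(Br)cc3)n2)ccc1F`) at 33900 nM and compound 3 (`COc1cc(-c2nc(-c3ccccc3)[nH]c2-c2ccnc(NCCCNS(=O)(=O)c3cccc4ccccc34)n2)ccc1F`) at 14900 nM. Compound 4 (`O=S(=O)(NCCCNc1nccc(-c2[nH]c(-c3ccccc3)nc2-c2ccc(F)c(O)c2)n1)c1ccc(Cl)cc1`) carries hydrogen in place of methyl on an oxygen on an aromatic ring, 4-fluoro-3-methoxyphenyl to 4-fluoro-3-hydroxyphenyl: hydrogen in place of methyl on an oxygen on an aromatic ring. The measured steps, a 2.5-fold lower number from compound 1 to compound 2 (0.39 log units; beyond the scatter) and a 5.6-fold lower number from compound 1 to compound 3 (0.75 log units; beyond the scatter), are modest and leave that group untouched, so they bound the expected size only loosely and fix no direction. With compound 1 at 83100 nM, a small lean to a lower number is expected. The expected change is a 1.5-fold lower number from compound 1 to compound 4 (0.18 log units; within the scatter). For compound 4 the estimate is 55000 nM, with an expected range of 18000 nM to 160000 nM.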

Compound 4, half-maximal inhibitory concentration: 14200 nM
The estimate for compound 4 lay 3.9-fold (0.59 log units) above the measured number; measured number outside the range, below it.
By their numbers in this assay, from the lowest: compounds 4 and 3 (each within the scatter of the next); then compound 2; then compound 1.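

In this assay the change at this oxygen gives a step beyond the scatter toward a lower number (a 5.9-fold lower number from compound 1 to compound 4 (0.77 log units; beyond the scatter)). Going by these compounds alone, the 4-fluoro-3-methoxyphenyl group is therefore not a silent part of the series, which the earlier steps could not show, as they changed only the group on the sulfonyl sulfur. Going by these compounds, whether the same change carries over to compound 2 or compound 3 stays open, as does the outcome with an ethoxy group or an amine at this place. Nothing measured here bears on the cause of this step.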